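Compound 2 to compound 3: fluoro in place of chloro

The source may report more compounds than this note shows. Statements on the series, on what has been measured and on what is new or still open speak of the compounds shown alone.

Compound 1 `COc1ccc(CSc2nnc([C@@H](C)c3ccc4cc(OC)ccc4c3)n2-c2ccc(Cl)cc2)cc1`: <= 400000 nM, a limit
Compound 2 `COc1ccc2cc([C@H](C)c3nnc(SCc4ccc(Cl)cc4)n3-c3ccc(Cl)cc3)ccc2c1`: 110000 nM

Within the data shown here, in a functional assay on LNCaP cells (Homo sapiens) for cytotoxicity, read by MTT assay (on this read-out lower numbers stand for stronger inhibition and higher numbers for weaker inhibition), compound 2 gives 110000 nM, the only true number so far. The entry for compound 1 is a limit. Compound 3 `COc1ccc2cc([C@H](C)c3nnc(SCc4ccc(F)cc4)n3-c3ccc(Cl)cc3)ccc2c1` is compound 2 with 4-fluorobenzyl in place of 4-chlorobenzyl: fluoro in place of chloro on an aromatic carbon. Among the measured compounds shown here, the one measured step, a step that the limit leaves unreadable from compound 1 to compound 2, is a change at the same place, but its size cannot be read, so it gives no direction. No change beyond the scatter is therefore expected, and the estimated step is no change at the digits printed from compound 2 to compound 3 (within the scatter). Compound 3 is expected at 110000 nM, with an estimated range of 40000 nM to 300000 nM.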

Compound 3, half-maximal inhibitory concentration: 33900 nM
For compound 3 the middle estimate is 3.2-fold (0.51 log units) above the measured one; the measured number lies below the stated range.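

In this assay, the benzyl substituent gives its first readable step: a 3.2-fold lower number from compound 2 to compound 3 (0.51 log units; beyond the scatter). A change of one halogen for another on this aromatic carbon is therefore enough to move the number beyond the scatter. Neither step from compound 1 can be read, as its entry is a limit, so methoxy remains unplaced against chloro or fluoro: the limit of <= 400000 nM in this assay, at which 1 of the 3 values shown sits.

Still open, going by these compounds, is how a nitrile or an amine on the same aromatic carbon would compare. Also open, on these data alone, is whether fluoro in place of chloro on the other 4-chlorophenyl group would give a similar step.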